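Swapping the aryl amide in a sulfamoylurea series

The source may report more compounds than this note shows. Statements on the series, on what has been measured and on what is new or still open speak of the compounds shown alone.

Of the compounds shown here, two of one series have been tested in a functional assay on the whole organism (blood) with Rattus norvegicus as the target, with stated times of 24 h and 1 h, at a dose of 5 mg/kg by the intraperitoneal route; on this read-out higher numbers stand for a stronger effect at the one dose given and lower numbers for a weaker effect. Compound 1 `Cc1ncsc1C(=O)NCCC1CCN(S(=O)(=O)NC(=O)NC[C@@H]2C[C@@H]3C=C[C@@H]2C3)CC1` gives 11% in this assay, and compound 2 `Cc1ncccc1C(=O)NCCC1CCN(S(=O)(=O)NC(=O)NC[C@@H]2C[C@@H]3C=C[C@@H]2C3)CC1` gives 16%. Among the measured compounds shown here, the one step between them, a number 5 percentage points higher from compound 1 to compound 2 (within the scatter), concerns the 2-methylpyridin-3-yl that replaces 4-methyl-1,3-thiazol-5-yl on a carbonyl carbon; the two numbers therefore lie within the scatter of each other, and compound 2 is simply one of two similar readings.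

Compound 3 `O=C(NC[C@@H]1C[C@@H]2C=C[C@@H]1C2)NS(=O)(=O)N1CCC(CCNC(=O)c2cc(Cl)ccn2)CC1` has not yet been measured in this assay. It differs from compound 2 in one place: 4-chloropyridin-2-yl in place of 2-methylpyridin-3-yl on a carbonyl carbon. For the measured compounds named here, no measured step touches the 4-chloropyridin-2-yl group, so the only guide is that the one aryl exchange seen so far, from compound 1 to compound 2, moved the number by an amount within the scatter. On that basis compound 3 is expected to stay near compound 2, with an estimated step of a number 2 percentage points lower from compound 2 to compound 3 (within the scatter) in this assay. Compound 3 is thus estimated at 14% in this assay, with a range from 3% to 27%.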

Compound 3, a percentage reported as activity, at one dose (the size of the read-out at that dose, not a potency): 32%
Estimate against measurement, compound 3: 18 percentage points below; measured number above the stated range.
By their numbers in this assay, from the lowest: compounds 1 and 2 (each within the scatter of the next); then compound 3.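

The aryl group on this carbonyl carbon is not a silent position in this assay after all: 4-chloropyridin-2-yl in place of 2-methylpyridin-3-yl gives a number 16 percentage points higher from compound 2 to compound 3 (beyond the scatter) and, in place of 4-methyl-1,3-thiazol-5-yl, it gives a number 21 percentage points higher from compound 1 to compound 3 (beyond the scatter) in the same read-out. The change from compound 2 to compound 3 keeps the six-membered aromatic ring with 1 hetero atom, the 7 heavy atoms and the hydrogen-bond counts, so what differs is a chlorine entering, a carbon leaving and a different substitution in the group's name. Nothing measured on these compounds bears on what lies behind this rise.

The compounds shown leave open whether the chlorine or the pyridin-2-yl attachment carries the difference, and a plain pyridin-2-yl or a 4-methylpyridin-2-yl on the same carbonyl carbon would separate the two. They also leave open whether the gap in this assay would hold at another dose, as each reading gives the size of the effect at the one dose and not a potency.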